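The compounds below may be only part of what the source reports. "The series", "measured", "known", "first", "only" and "open" are said of these compounds alone.

The compounds here share a core made of a fused two-ring system that carries a cyclic amide and is joined to a further aromatic ring. Among the measured compounds shown here, compound 1 `COc1ncc(-c2ccc3c(c2)NC(=O)CO3)cc1NS(=O)(=O)c1ccc(F)cc1` is the only member with a numerical result: in a functional assay on HCT-116 cells (Homo sapiens) for antiproliferative activity, read by MTT assay, with a stated time of 72 h (a lower number here means a stronger inhibitor, a higher number a weaker inhibitor), compound 1 gives 24900 nM. Compound 2 `O=C1COc2ccc(-c3cnc4ccccc4c3)cc2N1c1ccc(F)cc1` returns in this assay only > 40000 nM, which is a limit of the assay rather than a number, (the limit of > 40000 nM in this assay, at which 1 of the 2 values shown sits). Compound 1 therefore stands as the single measured point against which a new analogue can be judged.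

Compound 3 `COc1ncc(-c2ccc3c(c2)N(C(C)C)C(=O)CO3)cc1NS(=O)(=O)c1ccc(F)cc1` differs from compound 1 in one place: isopropyl in place of hydrogen on an amide-type nitrogen in a ring. For the measured compounds named here, no pair of measured compounds maps this change, so its effect in this assay is open. The added branched chain is small, and nothing among the two measured compounds shows that such a change would move the result beyond the usual scatter in either direction. Compound 3 is accordingly expected to land near compound 1, at an estimated 30000 nM, within a range of 8000 nM to 100000 nM. The expected step is a 1.2-fold higher number from compound 1 to compound 3 (0.08 log units; within the scatter).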

Compound 3, half-maximal inhibitory concentration: 19200 nM
The estimate for compound 3 lay 1.6-fold (0.19 log units) above the measured number; low and high end bracket the measured number.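

Putting isopropyl in place of hydrogen on the amide-type nitrogen in the ring gives, in this assay, a 1.3-fold lower number from compound 1 to compound 3 (0.11 log units; within the scatter). Among the compounds shown here, this is the first measured pair at this position, and it shows that the nitrogen can carry this branched chain with no change beyond the usual scatter. The amide hydrogen, absent from compound 3, is therefore not needed to keep the result at the level of compound 1 in this assay.

On these data alone, a single step within the scatter gives no direction, so it remains open whether a longer chain such as n-butyl, or a chain ending in an amine or a carboxylic acid, would leave the number where it is or move it on this nitrogen. Nothing among the data shown bears on why this change leaves the result within the scatter.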